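This account rests on a few compounds, and the source may have more. Where it says the series, first, only, none or still open, it means among the compounds named here.

Measured so far:
compound 1 `C=CCCCCCC#CC#CCO` — 9.79 ug/mL
compound 2 `CCCCCCCC#CC#CCO` — 4.63 ug/mL
compound 3 `CCCCCCCC#CC#CC(O)CC(C)=O` — 1.81 ug/mL

In a functional assay on SK-OV-3 cells (Homo sapiens) for cytotoxicity (a lower number here means that less compound is needed, a higher number that more compound is needed for the effect), compound 2 holds the second highest of the three numbers. Against compound 1 the change is a 2.1-fold lower number from compound 1 to compound 2 (0.33 log units; beyond the scatter); against compound 3 it is a 2.6-fold lower number from compound 2 to compound 3 (0.41 log units; beyond the scatter), and that is the wider gap.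

Compound 4 `CCCCCCCC#CC#CCOCC(=O)OC` differs from compound 2 in one place: (methoxycarbonyl)methyl in place of hydrogen on an oxygen on a saturated carbon. The step from compound 2 to compound 3 bears on this most, since there too a carbonyl-bearing group entered at the end of the chain carrying the oxygen, with a 2.6-fold lower number from compound 2 to compound 3 (0.41 log units; beyond the scatter); the step from compound 1 to compound 2 lies at the other end of the chain and bears less. A modest lower number is therefore expected for compound 4, about a 1.7-fold lower number from compound 2 to compound 4 (0.22 log units; within the scatter). The estimate for compound 4 in this assay is 2.8 ug/mL, with a range of 1.3 ug/mL to 6 ug/mL.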

Compound 4, concentration for half-maximal effect: 20.5 ug/mL
Beside the measured number, compound 4's estimate is 7.3-fold (0.86 log units) below it; the whole stated range lies below it.
By their numbers in this assay, from the lowest: compound 3; then compound 2; then compound 1; then compound 4.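

In this assay, (methoxycarbonyl)methyl in place of hydrogen on the oxygen gives a 4.4-fold higher number from compound 2 to compound 4 (0.65 log units; beyond the scatter), the opposite direction to a 2.6-fold lower number from compound 2 to compound 3 (0.41 log units; beyond the scatter), where 2-oxopropyl entered on the saturated chain carbon bound to that oxygen and the hydroxy stayed. Among these compounds, a carbonyl-bearing group at this end of the chain does not move the number one way, and the place of entry counts. No measurement at hand accounts for this difference.

Going by these compounds, whether the higher number follows from substitution on the oxygen itself or from this particular group remains open. A methyl ether or a carboxylic acid in place of the methyl ester would separate the two.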